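This account rests on a few compounds, and the source may have more. Where it says the series, first, only, none or still open, it means among the compounds named here.

Compound 1 `N#Cc1cnc(NCc2cnccc2C(F)(F)F)cc1N[C@H]1CC[C@@H](O)CC1`: 6%
Compound 2 `N#Cc1cnc(NCc2ccccc2C(F)(F)F)cc1N[C@H]1CC[C@@H](C(N)=O)CC1`: 3%

In an ADME assay on S9 fraction from liver (Rattus norvegicus) for metabolic stability, with a stated time of 1 h (a lower number here means that less of the compound is left, a higher number that more of the compound is left), compound 2 gives 3% and compound 1 gives 6%. These two values lie within the usual scatter of each other, and both show that little compound is left at the end of the assay.

Compound 3 `N#Cc1cnc(NCc2cnccc2C(F)(F)F)cc1N[C@H]1CC[C@@H](C(N)=O)CC1` is compound 2 with 4-(trifluoromethyl)pyridin-3-yl in place of 2-(trifluoromethyl)phenyl on a saturated chain carbon bound to a nitrogen on an aromatic ring. Going by the values given here, no measured pair shows this change on its own, so the expectation rests on thin evidence. Compound 1 also carries the 4-(trifluoromethyl)pyridin-3-yl group, and its 6% is a low number in this assay. The expected a number 2 percentage points higher from compound 2 to compound 3 (within the scatter) is therefore small, with no change beyond the scatter. For compound 3 the estimate is 5%, with an expected range from 1% to 15%.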

Compound 3, percent of the compound remaining: 30%
Beside the measured number, compound 3's estimate is 25 percentage points below it; the whole stated range lies below it.
By their numbers in this assay, from the lowest: compounds 2 and 1 (each within the scatter of the next); then compound 3.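

In this assay, 4-(trifluoromethyl)pyridin-3-yl in place of 2-(trifluoromethyl)phenyl gives a number 27 percentage points higher from compound 2 to compound 3 (beyond the scatter) when the carbamoyl group stays the same, so the group on this saturated chain carbon can matter for how much compound is left. With 4-(trifluoromethyl)pyridin-3-yl kept, carbamoyl in place of hydroxy on a saturated ring carbon gives a number 24 percentage points higher from compound 1 to compound 3 (beyond the scatter) and so shows that this second place matters too. Compound 1 and compound 2 differ in both places at once, so their values could not separate these two changes. Nothing available explains either step.

Going by these compounds, each step rests on a single pair, so it remains open whether the change of aromatic group would give a similar step with hydroxy on the saturated ring. Also open, on these data alone, is what an amine or a carboxylic acid on that ring carbon would give.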